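The source may report more compounds than this note shows. Statements on the series, on what has been measured and on what is new or still open speak of the compounds shown alone.

Measured so far in a functional assay on HepG2 cells (Homo sapiens) for antiproliferative activity, read by MTT assay, with a stated time of 48 h; a higher number here means a weaker inhibitor, a lower number a stronger inhibitor:

Compound 1 `O=[N+]([O-])c1cc(C(F)(F)F)cc([N+](=O)[O-])c1Oc1ccc(Br)cc1/C=N\OCc1ccccc1F` gives 890 nM.
Compound 2 `O=[N+]([O-])c1cc(C(F)(F)F)cc([N+](=O)[O-])c1Oc1ccc(Br)cc1/C=N/OCc1ccccc1Cl` gives 1240 nM.
Compound 3 `O=[N+]([O-])c1cc(C(F)(F)F)cc([N+](=O)[O-])c1Oc1c(Cl)cc(Cl)cc1/C=N\OCc1ccccc1F` gives 820 nM.

Compound 1 and compound 2 share one core and differ in a single place: a group of 11 heavy atoms (8 carbon, 1 nitrogen, 1 oxygen, 1 chlorine; one six-membered aromatic ring of carbon only) in place of a group of 11 heavy atoms (8 carbon, 1 nitrogen, 1 oxygen, 1 fluorine; one six-membered aromatic ring of carbon only), on an aromatic carbon. That change produced a 1.4-fold higher number from compound 1 to compound 2 (0.14 log units; within the scatter), so the two values cannot be told apart with confidence. Compound 3 is built on a second core; how the two cores differ is not broken down here. Its value and that of compound 1 are close enough that neither can be called the stronger.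

Compound 4 `O=[N+]([O-])c1cc(C(F)(F)F)cc([N+](=O)[O-])c1Oc1c(Cl)cc(Cl)cc1/C=N/OCc1ccccc1Cl` has not yet been measured in this assay. It stands to compound 3 as compound 2 stands to compound 1: a group of 11 heavy atoms (8 carbon, 1 nitrogen, 1 oxygen, 1 chlorine; one six-membered aromatic ring of carbon only) in place of a group of 11 heavy atoms (8 carbon, 1 nitrogen, 1 oxygen, 1 fluorine; one six-membered aromatic ring of carbon only), on an aromatic carbon. This is the same kind of change, not the same one, since the surroundings of the place differ: in compound 1 the place is meta to a bromo group, whereas in compound 3 it is meta to two chloro groups.

The step expected from compound 3 to compound 4 is a 1.4-fold higher number from compound 3 to compound 4 (0.15 log units; within the scatter), set beside the earlier one. This expectation rests on compound 1 and compound 2 because a 1.4-fold higher number from compound 1 to compound 2 (0.14 log units; within the scatter) was observed there, and on the closeness of compound 3 to compound 1 in this assay. Compound 4 is therefore estimated to give 1150 nM, with a likely range from 600 nM to 2300 nM.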

Compound 4, half-maximal inhibitory concentration: 1120 nM
Compound 4: middle estimate off by 1.0-fold (0.01 log units), on the high side; low and high end bracket the measured number.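

In this assay, the exchange of the fluorine-bearing group for the chlorine-bearing group on the core of compound 3 gave a 1.4-fold higher number from compound 3 to compound 4 (0.14 log units; within the scatter). Set beside the earlier step on the core of compound 1, the change carried over from one core to the other with no difference that can be detected: the same change on two cores in this assay, a 1.4-fold higher number (0.14 log units; within the scatter) from compound 1 to compound 2 and a 1.4-fold higher number (0.14 log units; within the scatter) from compound 3 to compound 4, 1.0-fold (0.01 log units) apart, within the scatter of two such steps. Each step lies within the scatter, so this agreement is one between two small, unresolved steps and not a real shift repeated; it shows that the exchange did not separate the values on either core, but it does not show that chlorine and fluorine differ here, and two cores cannot establish a rule for the whole series.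

The compounds shown leave open whether a step beyond the scatter would appear with a methoxy group, a nitrile or an amine in place of the halogen on that aromatic ring, or with a longer chain in place of the whole group. They also leave open how the same exchange behaves on any core other than these two.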